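Swapping the thioester of compound 2 for a propyl ketone

The source may report more compounds than this note shows. Statements on the series, on what has been measured and on what is new or still open speak of the compounds shown alone.

Within the data shown here, compound 2, `COC(C)(C)CCCC(C)C/C=C/C(C)=C/C(=O)SC(C)C`, stands highest of the two numbers so far in a physicochemical assay for lipophilicity (on this read-out lower numbers stand for lower lipophilicity and higher numbers for higher lipophilicity), giving 7.19. Among the measured compounds shown here, its only measured neighbour is compound 1, `CCOC(=O)/C=C(C)/C=C/CC(C)CCCC(C)(C)OC`, which in this assay gives 5.54; the single known step, a number 1.65 log units higher from compound 1 to compound 2 (beyond the scatter), is large and beyond the scatter. Compound 3, `CCCC(=O)/C=C(C)/C=C/CC(C)CCCC(C)(C)OC`, has not yet been measured in this assay. It differs from compound 2 at one place: propyl in place of isopropylsulfanyl on a carbonyl carbon. For the measured compounds named here, no measured step matches this change exactly. The step from compound 1 to compound 2 concerns the same carbonyl carbon and shows how strongly the group on it can move the read-out, but it exchanged ethoxy for isopropylsulfanyl, not isopropylsulfanyl for propyl. Since propyl carries no sulfur and no hydrogen-bond acceptor, compound 3 is expected to fall below compound 2 by a moderate amount, a number 0.64 log units lower from compound 2 to compound 3 (beyond the scatter), while staying above compound 1 on account of 5.54 for compound 1. Compound 3 is therefore estimated at 6.55, within a range from 5.9 to 7.2.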

Compound 3, partition coefficient: 5.61
Compound 3: the middle estimate sits 0.94 log units above what was measured; the whole stated range lies above it.
By their numbers in this assay, from the lowest: compounds 1 and 3 (each within the scatter of the next); then compound 2.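

The result shows that the large change at this carbonyl carbon is not tied to the ethoxy group alone: in this assay, replacing isopropylsulfanyl with propyl gives a number 1.58 log units lower from compound 2 to compound 3 (beyond the scatter), a step of similar size to the earlier one and opposite in direction. The third group also separates ethoxy from propyl, and the exchange between them gives only a number 0.07 log units higher from compound 1 to compound 3 (within the scatter), so compound 1 and compound 3 cannot be told apart on this read-out and, among the three groups compared here, only isopropylsulfanyl stands apart. Nothing presented here explains why this group stands apart.

Isopropylsulfanyl differs from propyl in both its sulfur atom and its branched shape, so these compounds leave open whether the step follows the sulfur, the branching or the two together, a question that an isopropyl or a propylsulfanyl group on the same carbonyl carbon could help to settle. Also open, from the compounds shown here alone, is where an amine at this carbon would fall, and whether the same exchanges would give steps of this size on any core other than the one shared by these three compounds.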